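Replacing Oxan-3-yl with 3-Cyanophenyl in Compound 4

A few compounds are considered here, and "the series" means these few. Any claim that something is new, unique, unknown or untested is made for them only; others in the source may bear on it.

Compound 1 `CNC(=O)c1cc(C(=O)NC2CC2)cn(CC2CCCOC2)c1=O` was measured in a physicochemical assay for lipophilicity, at pH 7.4 (on this read-out higher numbers stand for higher lipophilicity and lower numbers for lower lipophilicity), where compound 1 gives 2, the lowest of the three numbers. Compound 3 `CCNC(=O)c1cc(C(=O)NC)c(=O)n(Cc2ccccc2)c1` gives 3 and compound 2 `CNC(=O)c1cc(C(=O)NC2CCC2)cn(Cc2ccccc2)c1=O` gives 3.8. Among the compounds with values here, the only single-point step among the measured compounds, a number 0.80 log units lower from compound 2 to compound 3 (beyond the scatter), concerns the amide side and does not bear on the change considered here. Compound 4 `CNC(=O)c1cc(C(=O)NC2CC2)cn(Cc2cccc(C#N)c2)c1=O` differs from compound 1 in one place: 3-cyanophenyl in place of oxan-3-yl on a saturated chain carbon bound to an aromatic nitrogen. Within the data shown here, no measured pair isolates this change; compounds 1 and 2 differ in the group on that saturated chain carbon and also in the amide group, and their values lie far apart. A rise beyond the scatter is therefore expected, estimated as a number 0.80 log units higher from compound 1 to compound 4 (beyond the scatter). For compound 4 the expected value is 2.8, within a range from 2.3 to 3.4.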

Compound 4, distribution coefficient: 2.6
For compound 4 the middle estimate is 0.20 log units above the measured one; the range from low to high includes it.
By their numbers in this assay, from the lowest: compound 1; then compound 4; then compound 3; then compound 2.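

Within the data shown here, this pair gives the first reading of a change at this position alone: with the rest of the molecule the same, this assay shows a number 0.60 log units higher from compound 1 to compound 4 (beyond the scatter). The group on the saturated chain carbon bound to an aromatic nitrogen can therefore move this read-out beyond the scatter by itself, although this rests on a single pair. Nothing at hand accounts for the size of the step. Still open, on these data alone, is how far the nitrile contributes to the step, and how an amine or a carboxylic acid in place of 3-cyanophenyl would read.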